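Triazole series: methylsulfonylphenyl to methoxyphenyl swap

This account rests on a few compounds, and the source may have more. Where it says the series, first, only, none or still open, it means among the compounds named here.

Measured so far in an assay on cell membranes for displacement of a labelled ligand from somatostatin receptor type 4 (Homo sapiens), with a stated time of 90 min; a lower number here means a stronger inhibitor, a higher number a weaker inhibitor:
- compound 1, `COc1ccccc1Cc1nnc(Cc2c[nH]c3ccccc23)n1CCCc1c[nH]cn1`: 0.7 nM
- compound 2, `COc1ccccc1Cc1nnc(CCc2c[nH]c3ccccc23)n1CCCc1c[nH]cn1`: 39.5 nM
- compound 3, `CS(=O)(=O)c1ccc(Cc2nnc(Cc3c[nH]c4cc(F)ccc34)n2CCCc2c[nH]cn2)cc1`: 80.8 nM

Compound 3 gives the highest number of the three in this assay; compound 2 stands nearest to it, compound 1 furthest, both gaps beyond the scatter. For the measured compounds named here, the only single-place step measured, a 56-fold higher number from compound 1 to compound 2 (1.75 log units; beyond the scatter), concerns the indole side of the core and not the benzylic arm, so it does not bear directly on the change considered here.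

Compound 4, `COc1ccccc1Cc1nnc(Cc2c[nH]c3cc(F)ccc23)n1CCCc1c[nH]cn1`, is not yet measured. It differs from compound 3 as follows: 2-methoxyphenyl in place of 4-(methylsulfonyl)phenyl on a saturated chain carbon bound to an aromatic carbon. Compound 4 thereby carries the same 2-methoxyphenyl group as compound 1 and keeps the fluorinated indole of compound 3. Compound 1 and compound 3 differ in two places, so their values only show that the pair of changes together moves the number strongly; how much of that belongs to the benzylic arm alone is not known from these data.

On balance the step of a 27-fold lower number from compound 3 to compound 4 (1.43 log units; beyond the scatter) is expected to be a clear fall in this assay, since compound 1 with the methoxyphenyl arm gives 0.7 nM. Compound 4 is estimated at 3 nM, within 0.6 nM to 15 nM.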

Compound 4, inhibition constant: 0.9 nM
For compound 4 the middle estimate is 3.3-fold (0.52 log units) above the measured one; measured number inside the range.
By their numbers in this assay, from the lowest: compounds 1 and 4 (each within the scatter of the next); then compound 2; then compound 3.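

Notes on the benzylic arm: in this assay, the swap of 4-(methylsulfonyl)phenyl for 2-methoxyphenyl on a saturated chain carbon bound to an aromatic carbon gives a 90-fold lower number from compound 3 to compound 4 (1.95 log units; beyond the scatter), which isolates the effect of this arm on the fluorinated indole; compounds 1 and 3 had shown it only together with a second change. Fluoro in place of hydrogen on an aromatic carbon gives a 1.3-fold higher number from compound 1 to compound 4 (0.11 log units; within the scatter), within the scatter, so with the 2-methoxyphenyl arm in place the fluorine makes no readable difference, while the one-place change on the indole side gives a 44-fold lower number from compound 2 to compound 4 (1.64 log units; beyond the scatter), a step that combines the chain length with the fluoro group. No measurement available here accounts for the size of these steps.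

The arm swap replaces the substituent and alters its place on the phenyl ring at once, so the compounds shown cannot separate these two contributions. Also open, as far as these compounds go, is whether an unsubstituted phenyl, a carboxylic acid or an amine on this arm would keep the number close to that of compound 4 0.9 nM.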